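Adding a Second Methoxy: From Compound 2 to Compound 3

The source may hold more compounds than are shown below. What is called first, only, known or untested is meant among the compounds shown, and "the series" means these compounds.

Compound 1 `O=C1N=C(N2N=C(c3ccccc3)CC2c2ccccc2O)S/C1=C1/C(=O)Nc2ccc(Br)cc21`: 720 nM
Compound 2 `COc1ccc(C2CC(c3ccccc3)=NN2C2=NC(=O)/C(=C3\C(=O)Nc4ccc(Br)cc43)S2)cc1`: 390 nM

Of the compounds shown here, two have been measured in a functional assay on cells (Cancer cell lines, Homo sapiens) for cytotoxicity, read by sulforhodamine B assay, with a stated time of 48 h; on this read-out higher numbers stand for weaker inhibition of growth and lower numbers for stronger inhibition of growth. Compound 1 gives 720 nM there, and compound 2 gives 390 nM. Going by the values given here, compound 2 stands with its only neighbour, compound 1, within the scatter: a 1.8-fold lower number from compound 1 to compound 2 (0.27 log units; within the scatter). Compound 3 `COc1ccc(C2=NN(C3=NC(=O)/C(=C4\C(=O)Nc5ccc(Br)cc54)S3)C(c3ccc(OC)cc3)C2)cc1` differs from compound 2 by methoxy in place of hydrogen on an aromatic carbon. Among the compounds with values here, the one measured step, which also changed a substituent on a phenyl ring, remained within the scatter, so compound 3 is expected to show a 1.0-fold higher number from compound 2 to compound 3 (0.01 log units; within the scatter), no step beyond the scatter. Compound 3 is therefore estimated at 400 nM, with a range of 150 nM to 1100 nM.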

Compound 3, concentration for total growth inhibition: 405 nM
Compound 3: the middle estimate sits 1.0-fold (0.01 log units) below what was measured, within the range that was stated.
By their numbers in this assay, from the lowest: compounds 2, 3 and 1 (each within the scatter of the next).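

In this assay, the change from phenyl to 4-methoxyphenyl, on an aromatic carbon para to a large group, gives a 1.0-fold higher number from compound 2 to compound 3 (0.02 log units; within the scatter) and so adds a second methoxy with no step beyond the scatter. Going by these compounds alone, the earlier step concerned the aryl group on a saturated ring carbon, so this is the first reading at this position. Nothing available explains why this change stays within the scatter.

The compounds shown leave open whether an amine, a carboxylic acid or a longer chain at this position would also stay within the scatter.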